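A Saturated Ring in Place of an Aromatic One

The source may report more compounds than this note shows. Statements on the series, on what has been measured and on what is new or still open speak of the compounds shown alone.

Of the compounds shown here, three that share one core have been measured in an assay on isolated protein (Cavia porcellus) with Sigma non-opioid intracellular receptor 1 (Homo sapiens) as the target, read by radioligand binding; on this read-out lower numbers stand for stronger inhibition and higher numbers for weaker inhibition. Compound 1 `O=c1cc(-c2ccccc2Cl)oc2ccc(OCCCCCCN3CCC(O)CC3)cc12` gives 29 nM. Compound 2 `O=c1cc(-c2cccnc2)oc2ccc(OCCCCCCN3CCC(O)CC3)cc12` gives 210 nM. Compound 3 `O=c1cc(-c2ccc(F)cc2)oc2ccc(OCCCCCCN3CCC(O)CC3)cc12` gives 132 nM. Among these three numbers compound 3 has the second highest; its nearest neighbour is compound 2, and that gap lies within the scatter, a 1.6-fold lower number from compound 2 to compound 3 (0.20 log units; within the scatter), while its distance from compound 1 lies beyond it, a 4.6-fold higher number from compound 1 to compound 3 (0.66 log units; beyond the scatter).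

Compound 4 `O=c1cc(C2CCCC2)oc2ccc(OCCCCCCN3CCC(O)CC3)cc12` has not yet been measured. It differs from compound 3 in one place: cyclopentyl in place of 4-fluorophenyl on an aromatic carbon. The measured steps that bear on this are those at the same position, a 4.6-fold higher number from compound 1 to compound 3 (0.66 log units; beyond the scatter) and a 7.2-fold higher number from compound 1 to compound 2 (0.86 log units; beyond the scatter), each modest. Among the compounds with values here, all three measured groups there are aromatic rings, so no measured step shows what a non-aromatic ring does at that position. Since every change tried there moved the number by a modest amount, a modest shift is expected here too, with the direction uncertain but leaning towards a higher number in this assay. For compound 4 the estimate is 300 nM, within 80 nM to 1200 nM, which means an expected step of a 2.3-fold higher number from compound 3 to compound 4 (0.36 log units; beyond the scatter).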

Compound 4, half-maximal inhibitory concentration: 55 nM
The estimate for compound 4 lay 5.5-fold (0.74 log units) above the measured number, outside the stated range (below it).
By their numbers in this assay, from the lowest: compounds 1 and 4 (each within the scatter of the next); then compounds 3 and 2 (each within the scatter of the next).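

Cyclopentyl shows that the group at this position need not be aromatic in this assay: replacing an aromatic ring with this smaller, non-aromatic ring gives a 2.4-fold lower number from compound 3 to compound 4 (0.38 log units; beyond the scatter) and a 3.8-fold lower number from compound 2 to compound 4 (0.58 log units; beyond the scatter). Against the best of the aromatic groups, 2-chlorophenyl, the step is a 1.9-fold higher number from compound 1 to compound 4 (0.28 log units; within the scatter), so these two groups cannot be told apart in this assay, and a non-aromatic ring here matches the lowest number measured so far. Nothing available explains why cyclopentyl does better than 4-fluorophenyl or pyridin-3-yl.

As far as these compounds go, it remains open whether a cyclohexyl ring, or an open chain such as tert-butyl, would serve as well as cyclopentyl. An unsubstituted phenyl ring would also be informative, since it would separate the effect of the chlorine or fluorine from that of the aromatic ring itself.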